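Replacing the oxolan-3-yl group of compound 2

A few compounds are considered here, and "the series" means these few. Any claim that something is new, unique, unknown or untested is made for them only; others in the source may bear on it.

Among the measured compounds shown here, in a functional assay on HeLa cells (Homo sapiens) for cytotoxicity, read by MTT assay (on this read-out higher numbers stand for weaker inhibition and lower numbers for stronger inhibition), compound 1 `CC(=O)OCCC(=O)O[C@H](CC=C(C)C)C1=CC(=O)c2c(O)ccc(O)c2C1=O` gives 17300 nM and compound 2 `CC(C)=CC[C@@H](OC(=O)C1CCOC1)C1=CC(=O)c2c(O)ccc(O)c2C1=O` gives 73500 nM, the higher of the two numbers so far. The next change leads to compound 3 `CC(C)=CC[C@@H](OC(=O)CC(C)(O)C(C)C)C1=CC(=O)c2c(O)ccc(O)c2C1=O`, with 2-hydroxy-2,3-dimethylbutyl in place of oxolan-3-yl on a carbonyl carbon. The entering group has no ring. For the measured compounds named here, only one measured step bears on this: a 4.2-fold higher number from compound 1 to compound 2 (0.63 log units; beyond the scatter). It is modest but beyond the scatter, and it involves oxolan-3-yl at the same place, with 2-acetoxyethyl, also without a ring, on the lower-number side. Going by the values given here, a single step is thin evidence, and no measured compound carries the entering group. A modest move toward a lower number is therefore expected in this assay, with the expected step being a 2.7-fold lower number from compound 2 to compound 3 (0.43 log units; beyond the scatter). The estimate for compound 3 is 27000 nM, with an expected range from 9000 nM to 75000 nM.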

Compound 3, half-maximal inhibitory concentration: 27700 nM
Beside the measured number, compound 3's estimate is 1.0-fold (0.01 log units) below it; the measured number falls inside the stated range.
By their numbers in this assay, from the lowest: compounds 1 and 3 (each within the scatter of the next); then compound 2.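

In this assay there is a 2.7-fold lower number from compound 2 to compound 3 (0.42 log units; beyond the scatter) with 2-hydroxy-2,3-dimethylbutyl in place of oxolan-3-yl on the carbonyl carbon, so a second group with no ring now stands on the lower-number side of oxolan-3-yl. At this place, a 1.6-fold higher number from compound 1 to compound 3 (0.20 log units; within the scatter) leaves 2-acetoxyethyl and 2-hydroxy-2,3-dimethylbutyl unseparated, although the entering group has a hydrogen-bond donor and a different chain. No measurement shown explains the difference between oxolan-3-yl and the two groups with no ring.

Among the compounds shown here, with oxolan-3-yl as the only ring-bearing group, the ring cannot be separated from that particular group, and cyclopentyl would test this directly. As far as these compounds go, whether the plain 2,3-dimethylbutyl chain, an amine or a carboxylic acid would fit the same pattern remains open.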